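A Methyl Added to a Ring Nitrogen

The compounds below may be only part of what the source reports. "The series", "measured", "known", "first", "only" and "open" are said of these compounds alone.

Compound 1 `COc1cc(OC)c(-c2nc(N3CCNCC3)nc3ccccc23)c(OC)c1` gives 50 ug/mL in a functional assay on MCF7 cells (Homo sapiens) for antiproliferative activity, read by MTT assay; a higher number here means a weaker inhibitor, a lower number a stronger inhibitor
Compound 2 `Cn1cc(-c2nc(N3CCNCC3)nc3ccccc23)c2ccccc21` gives 50 ug/mL in this assay

On these numbers, compound 1 stands level with compound 2 at 50 ug/mL in this assay, and compound 2 has no measured neighbour that differs from it in one place. Compound 3 `CN1CCN(c2nc(-c3cn(C)c4ccccc34)c3ccccc3n2)CC1` changes compound 2 in a single spot, with piperazin-1-yl becoming 4-methylpiperazin-1-yl: methyl in place of hydrogen on an amine nitrogen in a ring is methyl in place of hydrogen on an amine nitrogen in a ring. Going by the values given here, no measured pair shows this change, so no step beyond the scatter is expected. The estimated change is a 1.1-fold lower number from compound 2 to compound 3 (0.05 log units; within the scatter) in this small series. For compound 3 the expected value is 45 ug/mL with an estimated range of 18 ug/mL to 100 ug/mL in this assay.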

Compound 3, half-maximal inhibitory concentration: 50 ug/mL
Estimate against measurement, compound 3: 1.1-fold (0.05 log units) below; measured number inside the range.
By their numbers in this assay, from the lowest: compounds 1, 2 and 3 (each within the scatter of the next).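

Methyl in place of hydrogen on the amine nitrogen of the piperazin-1-yl group gives no change at the digits printed from compound 2 to compound 3 (within the scatter) in this assay. Going by these compounds alone, this is the first pair here that differs in one place, so it gives the first direct reading at this ring nitrogen: adding one methyl does not move the number beyond the scatter. Nothing available explains this result. From the compounds shown here alone, whether a longer chain such as propyl, or a carboxylic acid carried on a short chain, would shift the number at this nitrogen remains open.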